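The source may report more compounds than this note shows. Statements on the series, on what has been measured and on what is new or still open speak of the compounds shown alone.

Measured compounds in an ADME assay on CHO-K1 cells (Cricetulus griseus) for cytotoxicity, read by MTT assay, with a stated time of 24 h; on this read-out lower numbers stand for higher toxicity in this test and higher numbers for lower toxicity in this test:

Compound 1, `Oc1ccccc1NC(=S)Nc1ccc2[nH]ccc2c1`, gives 509000 nM.
Compound 2, `Oc1ccc(NC(=S)Nc2ccc3[nH]ccc3c2)cc1Cl`, gives 447000 nM.
Compound 3, `Oc1cc(Cl)ccc1NC(=S)Nc1ccc2[nH]ccc2c1`, gives 251000 nM.

Compound 3 differs from compound 1 by one change, (chloro in place of hydrogen on an aromatic carbon), and that change made a 2.0-fold lower number from compound 1 to compound 3 (0.31 log units; beyond the scatter). The difference between the cores of compound 1 and compound 2 is not broken down here. The unmeasured compound 4, `Oc1c(Cl)cc(NC(=S)Nc2ccc3[nH]ccc3c2)cc1Cl`, differs from compound 2 by chloro in place of hydrogen on an aromatic carbon. This is the same kind of change, though the place is not identical: in compound 3 the chloro sits meta to a hydroxy group and para to a large group, whereas in compound 4 it sits ortho to a hydroxy group, meta to a chloro group and meta to a large group. Resting on compound 3 and its step of a 2.0-fold lower number from compound 1 to compound 3 (0.31 log units; beyond the scatter), a similar step is expected from compound 2, namely a 1.9-fold lower number from compound 2 to compound 4 (0.29 log units; within the scatter). Compound 4 is accordingly estimated at 230000 nM, between 120000 nM and 420000 nM.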

Compound 4, concentration lethal to 50% of the cells: 523000 nM
Compound 4: the middle estimate sits 2.3-fold (0.36 log units) below what was measured; the measured number lies above the stated range.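

Chloro in place of hydrogen on an aromatic carbon gave a 1.2-fold higher number from compound 2 to compound 4 (0.07 log units; within the scatter) in this assay. Set beside the earlier step, this result does not separate the two cores: the same change on two cores in this assay, a 2.0-fold lower number (0.31 log units; beyond the scatter) from compound 1 to compound 3 and a 1.2-fold higher number (0.07 log units; within the scatter) from compound 2 to compound 4, 2.4-fold (0.38 log units) apart, within the scatter of two such steps. The pair therefore gives no sign that the change behaves differently from one core to the other, but it does not establish that the step carries over, as each core offers a single pair and the chloro sits in a different place on each.

Going by these compounds, all four compounds keep the hydroxy group, so what a methoxy group or an amine in its place would do remains open. Also open, on these data alone, is whether bromo or methyl in place of the chloro would give a step beyond the scatter.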